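Ethyl in place of 2-methylcyclopropyl on compound 1

A few compounds are considered here, and "the series" means these few. Any claim that something is new, unique, unknown or untested is made for them only; others in the source may bear on it.

Measured so far in an ADME assay on microsomes from liver (Homo sapiens) for pharmacokinetics; on this read-out higher numbers stand for fast clearance and lower numbers for slow clearance
compound 1 `C[C@@H]1C[C@H]1C(=O)N1CCN(c2nc(-c3cnn(C)c3)ncc2C#N)C[C@H]1C` gives < 16 mL/min/kg (a limit)
compound 2 `Cn1cc(-c2ncc(C#N)c(N3C[C@@H]4C[C@H]3CN4c3cccc(F)c3)n2)cn1` gives 76 mL/min/kg
compound 3 `C[C@@H]1C[C@H]1C(=O)N1CCN(c2cnc(C#N)c(-c3cnn(C)c3)n2)C[C@H]1C` gives < 16 mL/min/kg (a limit)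

Compound 1 stands at the limit of < 16 mL/min/kg in this assay, at which 2 of the 3 values shown sit. Going by these compounds, that is a limit and not a true number, so how far its clearance lies under it remains unknown. Only compound 2 gives a true number. Compound 4 `CCC(=O)N1CCN(c2nc(-c3cnn(C)c3)ncc2C#N)C[C@H]1C` keeps the core of compound 1 but carries ethyl in place of 2-methylcyclopropyl on a carbonyl carbon. Within the data shown here, no measured pair shows this change alone. In this assay the expected step, a step that the limit leaves unreadable from compound 1 to compound 4, is none beyond the scatter. Compound 4 is estimated at 13 mL/min/kg, with an expected range from 7 mL/min/kg to 26 mL/min/kg.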

Compound 4, clearance: < 16 mL/min/kg
Compound 4 ended at the assay's limit (the forecaster's own chance of this, stated with the estimate: 70%); the middle value does not contradict the limit.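

Among these compounds, compound 1 and compound 4 both give a limit rather than a true number, so no step between them can be read: the limit of < 16 mL/min/kg in this assay, at which 3 of the 4 values shown sit. Going by these compounds, how far the clearance of each compound lies under that limit, and whether swapping 2-methylcyclopropyl for ethyl changes it at all, stays open.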